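Changing one aryl group on a shared core

The compounds below may be only part of what the source reports. "The series", "measured", "known", "first", "only" and "open" are said of these compounds alone.

Three compounds share a core and differ only in the aryl group on a nitrogen on an aromatic ring. Compound 1 `COc1cc(Br)ccc1Nc1cc(NC(=O)Nc2c(Cl)cccc2Cl)ncn1`, compound 2 `Cc1ccc(Nc2cc(NC(=O)Nc3c(Cl)cccc3Cl)ncn2)cc1F` and compound 3 `COc1ccc(Nc2cc(NC(=O)Nc3c(Cl)cccc3Cl)ncn2)cc1C` have all been tested in a functional assay on NCI-H520 cells (Homo sapiens) for inhibition, read by MTT assay, with a stated time of 48 h, tested at 10 uM; a lower number here means less inhibition, a higher number more inhibition at the concentration tested (going by the name of the read-out). In this assay compound 1 gives 29.1%, compound 2 gives 33.5% and compound 3 gives 29.1%. The steps between them are small: a number 4.4 percentage points higher from compound 1 to compound 2 (within the scatter), no change at the digits printed from compound 1 to compound 3 (within the scatter), and a number 4.4 percentage points lower from compound 2 to compound 3 (within the scatter). Compound 3 thus stands level with compound 1, the two together the lowest of the three numbers, with compound 2 furthest away yet still within the scatter.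

Compound 4 `Cc1cc(F)cc(Nc2cc(NC(=O)Nc3c(Cl)cccc3Cl)ncn2)c1` is not yet measured. It differs from compound 3 in one place: 3-fluoro-5-methylphenyl in place of 4-methoxy-3-methylphenyl on a nitrogen on an aromatic ring. All three measured steps bear on this, since each also swapped the aryl group on that nitrogen, and none of them moved the read-out beyond the scatter. A step of a number 1.9 percentage points higher from compound 3 to compound 4 (within the scatter) is therefore expected, that is, none beyond the scatter. Compound 4 is estimated to give 31%, within a range from 18% to 44%.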

Compound 4, a percentage reported as inhibition, at one concentration (the size of the read-out at that concentration, not a potency): 60.5%
The estimate for compound 4 lay 29.5 percentage points below the measured number, and the stated range ends below it.
By their numbers in this assay, from the lowest: compounds 1, 3 and 2 (each within the scatter of the next); then compound 4.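

The earlier steps shown here suggested that the aryl group on this nitrogen hardly mattered, but in this assay the 3-fluoro-5-methylphenyl group gives a number 31.4 percentage points higher from compound 3 to compound 4 (beyond the scatter) in place of 4-methoxy-3-methylphenyl. The rise also appears against the 4-bromo-2-methoxyphenyl group, with a number 31.4 percentage points higher from compound 1 to compound 4 (beyond the scatter) as the step. Even 3-fluoro-4-methylphenyl, which differs only in the numbering of its methyl group, gives a number 27 percentage points higher from compound 2 to compound 4 (beyond the scatter) on the way to the new group, so the same two substituents on this ring do not guarantee the same read-out, and no measurement at hand explains this.

From the compounds shown here alone, it remains open whether a chlorine or a nitrile could stand in for the fluorine of 3-fluoro-5-methylphenyl, or an ethyl or an amine for its methyl, and still keep the higher number. A single-concentration percentage also leaves the potency of compound 4 open.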